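Acetamide in Place of Thiocarbamate on the Saturated Ring

The source may hold more compounds than are shown below. What is called first, only, known or untested is meant among the compounds shown, and "the series" means these compounds.

Among the compounds with values here, compound 2 `CN(C)C(=S)OC1C[C@@H]2CCCC[C@@H]2[C@H]1/C=C/c1ccc(-c2cccc(F)c2)cn1` holds the lowest of the two numbers so far in an assay on cell membranes for displacement of a labelled ligand from proteinase-activated receptor 1 (Homo sapiens), read by scintillation counting, with a stated time of 60 min (a higher number here means a weaker inhibitor, a lower number a stronger inhibitor), where compound 2 gives 120 nM, while compound 1 `Fc1cccc(-c2ccc(/C=C/[C@H]3C(OCc4ccccc4)C[C@@H]4CCCC[C@@H]43)nc2)c1` gives 280 nM. Within the data shown here, the only step bearing on this site is a 2.3-fold lower number from compound 1 to compound 2 (0.37 log units; beyond the scatter). Compound 3 `CC(=O)NC1C[C@@H]2CCCC[C@@H]2[C@H]1/C=C/c1ccc(-c2cccc(F)c2)cn1` differs from compound 2 by a group of 4 heavy atoms (2 carbon, 1 nitrogen, 1 oxygen; no ring) in place of a group of 6 heavy atoms (3 carbon, 1 nitrogen, 1 oxygen, 1 sulfur; no ring), on a saturated ring carbon. One modest step at this position gives little guidance on direction, so no change beyond the scatter is expected. Compound 3 is therefore estimated at 180 nM, within a range from 60 nM to 600 nM. That estimate corresponds to an expected step of a 1.5-fold higher number from compound 2 to compound 3 (0.18 log units; within the scatter).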

Compound 3, half-maximal inhibitory concentration: 53 nM
Estimate against measurement, compound 3: 3.4-fold (0.53 log units) above, outside the stated range (below it).
By their numbers in this assay, from the lowest: compound 3; then compound 2; then compound 1.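

In this assay, within the data shown here, the acetamido group gives the lowest number so far on this saturated ring carbon, with a 2.3-fold lower number from compound 2 to compound 3 (0.35 log units; beyond the scatter) and a 5.3-fold lower number from compound 1 to compound 3 (0.72 log units; beyond the scatter). Of the three groups compared here, the one with the fewest heavy atoms, and the only one with a hydrogen-bond donor, gives the lowest number. No measurement shown here gives a reason for this gain.

From the compounds shown here alone, the amide hydrogen and the group's size change together, so their separate contributions remain open. A plain amine or a longer acyl chain on this carbon remains to be compared.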